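Cyclohexyl in Place of Methyl on an Amine Nitrogen

The source may report more compounds than this note shows. Statements on the series, on what has been measured and on what is new or still open speak of the compounds shown alone.

In an assay on cardiac atrium with histamine H2 receptor (Cavia porcellus) as the target (on this read-out lower numbers stand for smaller maximal responses and higher numbers for larger maximal responses), compound 1 `CN/C(=N\CCC(c1ccc(F)cc1)c1ccccn1)NCCCc1c[nH]cn1` gives 1.
In this assay compound 2 `Cc1ccc(CC(CC/N=C(/NCCCc2c[nH]cn2)NC2CCCCC2)c2ccccn2)cc1` gives 1.
In this assay compound 3 `CN/C(=N\CCC(c1ccc(Br)cc1)c1ccccn1)NCCCc1c[nH]cn1` gives 0.9.

Within the data shown here, compound 3 holds the lowest of the three numbers, yet all three lie within the scatter of one another: the one single-point step, a number 0.10 lower from compound 1 to compound 3 (within the scatter), is within the scatter, and compound 2 sits at the same distance from compound 3 as compound 1 does. All three compounds therefore reach essentially the full response of the reference agonist.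

Compound 4 `Brc1ccc(C(CC/N=C(/NCCCc2c[nH]cn2)NC2CCCCC2)c2ccccn2)cc1` differs from compound 3 by cyclohexyl in place of methyl on an amine nitrogen. Among the measured compounds shown here, no measured step isolates this change. For the measured compounds named here, compound 2 does carry cyclohexyl on the same nitrogen and gives 1 in this assay, but it also differs from compound 3 elsewhere, so it shows only that the cyclohexyl compounds seen so far remain full agonists. Going by the values given here, the only step measured, from fluoro to bromo, was within the scatter. For compound 4 the expected step is a number 0.050 higher from compound 3 to compound 4 (within the scatter), none beyond the scatter. Compound 4 is estimated at 0.95, between 0.8 and 1.05.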

Compound 4, intrinsic activity: the largest response reached, as a fraction of the reference agonist's: 0.65
Estimate against measurement, compound 4: 0.30 above, outside the stated range (below it).
By their numbers in this assay, from the lowest: compound 4; then compounds 3, 1 and 2 (each within the scatter of the next).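

In this assay, among these compounds, the amine nitrogen proved not to be a freely tolerant position: cyclohexyl in place of methyl gives a number 0.25 lower from compound 3 to compound 4 (beyond the scatter), the first step beyond the scatter. Cyclohexyl does not by itself bring this loss, since compound 2 carries it on the same nitrogen and gives 1, while 4-bromophenyl in place of 4-methylbenzyl on the saturated chain carbon gives a number 0.35 lower from compound 2 to compound 4 (beyond the scatter), so the outcome with cyclohexyl depends on the group at that carbon too. No evidence available here bears on the reason for these losses.

As far as these compounds go, it remains open whether a smaller ring such as cyclopentyl, or an open chain such as ethyl, on the same nitrogen would lower the maximal response as well. From the compounds shown here alone, it is also open whether cyclohexyl would have the same effect with fluoro in place of bromo on the aromatic carbon.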